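Aryl group changes on the amine nitrogen in the ring

A few compounds are considered here, and "the series" means these few. Any claim that something is new, unique, unknown or untested is made for them only; others in the source may bear on it.

Measured so far:
compound 1 `Nc1scc(CN2CCN(c3cccc(Cl)c3Cl)CC2)c1C(=O)c1ccc(Cl)cc1` with -77%
compound 2 `Nc1scc(CN2CCN(c3ccccc3C(F)(F)F)CC2)c1C(=O)c1ccc(Cl)cc1` with -60%
compound 3 `Nc1scc(CN2CCN(c3cc(F)cc(F)c3)CC2)c1C(=O)c1ccc(Cl)cc1` with -79%

The three share one core and differ only in the aryl group on the amine nitrogen in the ring. In a functional assay on CHO cells with adenosine receptor A1 (Homo sapiens) as the target, read by cAMP accumulation and immunoassay, with a stated time of 6 min, tested at 10 uM (a higher number here means a weaker effect of the compound at the concentration tested, a lower number a stronger effect), compound 1 gives -77%, the second highest of the three numbers. Compound 3 lies nearest with -79%, within the scatter of compound 1; compound 2 lies furthest with -60%, beyond the scatter. The steps read a number 2 percentage points lower from compound 1 to compound 3 (within the scatter), a number 17 percentage points higher from compound 1 to compound 2 (beyond the scatter) and a number 19 percentage points lower from compound 2 to compound 3 (beyond the scatter).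

Compound 4 `Nc1scc(CN2CCN(c3cc(F)ccc3F)CC2)c1C(=O)c1ccc(Cl)cc1` is not yet measured. It differs from compound 1 in one place: 2,5-difluorophenyl in place of 2,3-dichlorophenyl on an amine nitrogen in a ring.

Among the measured compounds shown here, two measured steps bear on this change. The swap of 2,3-dichlorophenyl for a difluorophenyl, a number 2 percentage points lower from compound 1 to compound 3 (within the scatter), stayed within the scatter. The swap for 2-(trifluoromethyl)phenyl, a number 17 percentage points higher from compound 1 to compound 2 (beyond the scatter), gave a modest rise. Compound 4 carries fluorine rather than chlorine, like compound 3, so the expectation in this assay is a small step, if any, leaning slightly higher: a number 7 percentage points higher from compound 1 to compound 4 (within the scatter). Compound 4 is therefore estimated at -70%, with a range from -85% to -52%.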

Compound 4, a percentage reported as activity, at one concentration (the size of the read-out at that concentration, not a potency): -80%
Beside the measured number, compound 4's estimate is 10 percentage points above it, and the stated range covers the measured number.
By their numbers in this assay, from the lowest: compounds 4, 3 and 1 (each within the scatter of the next); then compound 2.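

In this assay the 2,5-difluorophenyl group gives a number 3 percentage points lower from compound 1 to compound 4 (within the scatter) and a number 1 percentage points lower from compound 3 to compound 4 (within the scatter) so the difluorophenyl result no longer rests on 3,5-difluorophenyl alone, and a second fluorine arrangement cannot be told apart from either 2,3-dichlorophenyl or 3,5-difluorophenyl at this position on the amine nitrogen in the ring. The change from 2-(trifluoromethyl)phenyl gives a number 20 percentage points lower from compound 2 to compound 4 (beyond the scatter) which leaves compound 2 as the only one of the four set apart, with the dichlorophenyl and difluorophenyl compounds 1, 3 and 4 forming one group and compound 2 the exception. No measurement at hand accounts for this grouping or for the separate place of compound 2.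

The compounds shown do not separate the trifluoromethyl group itself from the presence of a single substituent on the aryl ring, so a 2-chlorophenyl or 2-fluorophenyl group would be the informative comparison. They also leave open whether the read-out holds with a methoxy group, a nitrile or an amine on the aryl ring, or with an unsubstituted phenyl, and a single tested concentration gives no potency order among compounds 1, 3 and 4.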